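Indolyl in place of cyclohexyl: solubility outlook

A few compounds are considered here, and "the series" means these few. Any claim that something is new, unique, unknown or untested is made for them only; others in the source may bear on it.

Compound 1 `CNC(=O)c1cc(C(=O)NC2CCOCC2)cn(Cc2ccccc2)c1=O` gives >= 174 ug/mL in a physicochemical assay for solubility (on this read-out lower numbers stand for lower solubility and higher numbers for higher solubility), which is a limit of the assay, not a number.
Compound 2 `CNC(=O)c1cc(C(=O)NC2CC2)cn(CC2CCCCC2)c1=O` gives >= 148 ug/mL in this assay, again a limit.
Compound 3 `CNC(=O)c1cc(C(=O)NC(C)C)cn(Cc2ccccc2)c1=O` gives >= 136 ug/mL in this assay, also a limit.

Compound 2 thus stands at the limit of >= 148 ug/mL in this assay, at which 1 of the 3 values shown sits; since every value shown is a limit, no order among the three compounds can be read. Compound 4 `CNC(=O)c1cc(C(=O)NC2CC2)cn(Cc2cccc3cc[nH]c23)c1=O` differs from compound 2 in one place: 1H-indol-7-yl in place of cyclohexyl on a saturated chain carbon bound to an aromatic nitrogen. Among the measured compounds shown here, the only measured step, a step that the two limits leave unreadable from compound 1 to compound 3, concerns the amide-type nitrogen and is left unreadable by the two limits, so no measured step bears on the saturated chain carbon bound to an aromatic nitrogen. The step from compound 2 to compound 4 is therefore expected to be an at least 2.4-fold lower number from compound 2 to compound 4 (0.39 log units; beyond the scatter), a downward move with wide uncertainty. Compound 4 is estimated at 60 ug/mL, with a range from 15 ug/mL to 200 ug/mL.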

Compound 4, solubility: >= 144 ug/mL
Compound 4: no number, only a limit; the forecaster's own chance of this, stated with the estimate: 30%; at least 2.4-fold (0.38 log units) between middle value and limit.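

Among the compounds shown here, compound 2 and compound 4 each give only a limit in this assay, so no step between them can be read. The compounds shown leave open whether 1H-indol-7-yl in place of cyclohexyl changes this read-out at all.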